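The source may report more compounds than this note shows. Statements on the series, on what has been measured and on what is new or still open speak of the compounds shown alone.

Measured in a functional assay on A549 cells (Homo sapiens) for cytotoxicity, read by MTT assay, with a stated time of 48 h; on this read-out higher numbers stand for weaker inhibition and lower numbers for stronger inhibition:
- Compound 1 `Cc1ccc(Cn2cc(COc3ccc4c(=O)ccoc4c3)nn2)cc1`: 50700 nM
- Compound 2 `Cc1ccccc1Cn1cc(COc2ccc3c(=O)ccoc3c2)nn1`: > 100000 nM, a limit of the assay
- Compound 3 `O=c1ccoc2cc(OCc3cn(Cc4cccc(F)c4)nn3)ccc12`: > 100000 nM, a limit of the assay

Compound 3 gives no number in this assay, only a limit, and compound 2 shares that position: the limit of > 100000 nM in this assay, at which 2 of the 3 values shown sit.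

Compound 4 `O=c1ccoc2cc(OCc3cn(Cc4ccc(F)cc4)nn3)ccc12` has the same atoms as compound 3, joined differently, with 4-fluorophenyl in place of 3-fluorophenyl on a saturated chain carbon bound to an aromatic nitrogen.

Going by the values given here, no measured step makes this exact change. The closest evidence comes from changes at the same place. The first is an at least 1.9-fold higher number from compound 1 to compound 3 (0.29 log units; that floor lies within the scatter), and the second is an at least 1.9-fold higher number from compound 1 to compound 2 (0.29 log units; that floor lies within the scatter). The floor of each lies within the scatter, so neither shows a real size. The third, a step that the two limits leave unreadable from compound 2 to compound 3, cannot be read at all. Among the compounds with values here, the only actual number belongs to compound 1, with its 4-methylphenyl, at 50700 nM, and this single compound is thin ground for a trend.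

A step beyond the scatter is therefore not expected, though any shift would most likely be towards a lower number. The expected step is an at least 1.2-fold lower number from compound 3 to compound 4 (0.09 log units; that floor lies within the scatter). For compound 4 the estimated value is 80000 nM, with an expected range from 35000 nM to 200000 nM.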

Compound 4, half-maximal inhibitory concentration: > 100000 nM
Compound 4: a limit, no number; the forecaster's own chance of this, stated with the estimate: 55%; middle value at least 1.2-fold (0.09 log units) away from the limit.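

The steps from compound 3 and from compound 2 to compound 4 cannot be read, as both ends of each are limits, so the change from 3-fluorophenyl to 4-fluorophenyl on a saturated chain carbon bound to an aromatic nitrogen has no size here. Going by these compounds alone, the one readable step, fluoro in place of methyl on an aromatic carbon, is an at least 1.9-fold higher number from compound 1 to compound 4 (0.29 log units; that floor lies within the scatter), so it shows no real size, and compound 1 remains the only one of the four with an actual number. What compound 4 adds is that 4-fluorophenyl, like 3-fluorophenyl in compound 3 and 2-methylphenyl in compound 2, ends at a limit of the assay and not at a number: the limit of > 100000 nM in this assay, at which 3 of the 4 values shown sit.

Still open, going by these compounds, are the true values of compound 2, compound 3 and compound 4, and whether the number of compound 1 reflects anything beyond that single compound. Also open, on these data alone, is what 4-chlorophenyl, 4-methoxyphenyl or a phenyl carrying an amine would give in this assay on a saturated chain carbon bound to an aromatic nitrogen.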